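Working notes: from compound 2 to compound 4

The source may report more compounds than this note shows. Statements on the series, on what has been measured and on what is new or still open speak of the compounds shown alone.

Measured so far in a functional assay on HeLa cells (Homo sapiens) for antiproliferative activity, read by MTT assay (on this read-out higher numbers stand for weaker inhibition and lower numbers for stronger inhibition), of this series:
compound 1 `COc1ccc(-c2ccnc(Nc3ccc([N+](=O)[O-])cc3)n2)cc1` gives 980 nM
compound 2 `O=[N+]([O-])c1ccc(Nc2nccc(-c3ccc(F)cc3)n2)cc1` gives 3510 nM
compound 3 `CC(C)c1ccccc1Nc1nccc(-c2ccc(Br)cc2)n1` gives 11500 nM

Compound 2 has the second highest of the three numbers, with compound 1 lower (980 nM) and compound 3 higher (11500 nM). The next structure is compound 4 `O=[N+]([O-])c1ccc(Nc2nccc(-c3ccc(Cl)cc3Cl)n2)cc1` with 2,4-dichlorophenyl in place of 4-fluorophenyl on an aromatic carbon and the rest of compound 2 unchanged.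

Going by the values given here, only one measured step bears on this place: a 3.6-fold higher number from compound 1 to compound 2 (0.55 log units; beyond the scatter) with fluoro in place of methoxy. It was modest. Among the compounds with values here, compound 3 differs from compound 2 in more than one place and offers no clean step. Within the data shown here, the single step shows that the number can move with a change on this ring, but it involves no chlorine and gives no direction here. No step beyond the scatter is therefore expected in this assay although the support is thin and the range is kept wide. The estimated change is a 1.2-fold lower number from compound 2 to compound 4 (0.07 log units; within the scatter) as an expectation only. For compound 4 the estimated value is 3000 nM (expected range 900 nM to 10000 nM).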

Compound 4, half-maximal inhibitory concentration: 168000 nM
Compound 4: the middle estimate sits 56-fold (1.75 log units) below what was measured, outside the stated range (above it).
By their numbers in this assay, from the lowest: compound 1; then compound 2; then compound 3; then compound 4.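

In this assay, this aromatic carbon of the shared core proves far more sensitive than the earlier fluoro for methoxy swap suggested: 2,4-dichlorophenyl in place of 4-fluorophenyl gives a 48-fold higher number from compound 2 to compound 4 (1.68 log units; beyond the scatter) on this read-out, a large step where a 3.6-fold higher number from compound 1 to compound 2 (0.55 log units; beyond the scatter) was only modest. The same group in place of 4-methoxyphenyl gives a 170-fold higher number from compound 1 to compound 4 (2.23 log units; beyond the scatter) and widens the span among the compounds that differ only at this place. No supporting measurement bears on the size of this loss.

Open, from the compounds shown here alone, is whether the loss follows both chlorines together or only one of them, which a 4-chlorophenyl or a 2-chlorophenyl group on the core of compound 2 would separate. Also open, going by these compounds, is how an aminophenyl or a hydroxyphenyl group would behave at this place.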